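The source may hold more compounds than are shown below. What is called first, only, known or untested is meant among the compounds shown, and "the series" means these compounds.

Measured so far:
compound 1, `N=C(S)CCCn1nc(-c2ccccc2)ccc1=O`: 75.6%
compound 2, `N=C(S)CCCCCCN1N=C(c2ccccc2)CCC1=O`: 68.3%

Both numbers come from a functional assay on the whole organism (stomach) for inhibition, with Rattus norvegicus as the target, at a dose of 100 mg/kg by the intraduodenal route; a lower number here means less inhibition, a higher number more inhibition at the dose given (going by the name of the read-out). Compound 1 gives 75.6% and compound 2 gives 68.3%; the two values cannot be told apart, since their gap lies within the usual scatter of this assay, so the inhibition in this assay is level for the two compounds.

The next compound, compound 3, is `N=C(S)CCCCCCn1nc(-c2ccccc2)ccc1=O`. It differs from compound 1 in one place: a group of 6 heavy atoms (4 carbon, 1 nitrogen, 1 sulfur; no ring) in place of a group of 3 heavy atoms (1 carbon, 1 nitrogen, 1 sulfur; no ring), on a saturated chain carbon, three bonds along the chain from an aromatic nitrogen. The rest of compound 1, its core and the thioamide end of the chain, is kept.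

Within the data shown here, no measured pair shows what a change of this kind does in this assay, so the expectation rests on the two numbers in hand. The step from compound 1 to compound 3 is expected to stay within the scatter, because compound 2 gives 68.3% and compound 1 gives 75.6%, a narrow band for compounds of this series. Compound 3 is therefore estimated at 70%, with a range from 55% to 85%, a step of a number 5.6 percentage points lower from compound 1 to compound 3 (within the scatter) that is expected to be no more than the scatter.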

Compound 3, a percentage reported as inhibition, in the whole organism at one dose (the size of the read-out at that dose, not a potency): 33.9%
Beside the measured number, compound 3's estimate is 36.1 percentage points above it; measured number below the stated range.
By their numbers in this assay, from the lowest: compound 3; then compounds 2 and 1 (each within the scatter of the next).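

Among these compounds, this is the first pair that differs in only one place, so it gives the first direct reading of this position. In this assay, placing the group of 6 heavy atoms where the group of 3 heavy atoms stood, on the saturated chain carbon, gives a number 41.7 percentage points lower from compound 1 to compound 3 (beyond the scatter) with the core and the thioamide end of the chain kept. The position is therefore not indifferent to chain length, and in this one pair the longer chain goes with much less inhibition at the dose given, although one pair cannot show how the effect changes along the chain; no measurement at hand explains the fall.

The compounds shown leave open whether inhibition falls gradually or abruptly, which a chain of intermediate length or a still longer chain would help to settle. They also leave open whether the thioamide end itself is needed at this position, a question that compounds carrying an amine or a carboxylic acid in its place on the same chain could address.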